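Chain length at the aromatic nitrogen and maximal response

The source may hold more compounds than are shown below. What is called first, only, known or untested is meant among the compounds shown, and "the series" means these compounds.

Measured so far in a functional assay on the whole organism with Mus musculus as the target; a lower number here means a smaller maximal response, a higher number a larger maximal response:
compound 3 `Cn1c(=O)n(C2OC(CO)[C@@H](O)[C@H]2O)c2nc(N)nc(O)c21` gives 100%
compound 1 `NC(=O)Cn1c(=O)n(C2OC(CO)[C@@H](O)[C@H]2O)c2nc(N)nc(O)c21` gives 72%
compound 2 `CCCCCCCCCCn1c(=O)n(C2OC(CO)[C@@H](O)[C@H]2O)c2nc(N)nc(O)c21` gives 0%

Compound 3 stands highest of the three in this assay; compound 1 lies a modest distance under it and compound 2 lies far under it. The next member, compound 4 `CCCCn1c(=O)n(C2OC(CO)[C@@H](O)[C@H]2O)c2nc(N)nc(O)c21`, differs from compound 3 by propyl in place of hydrogen on a saturated chain carbon bound to an aromatic nitrogen. The step that bears on this is a number 100 percentage points higher from compound 2 to compound 3 (beyond the scatter), which was large; a number 28 percentage points higher from compound 1 to compound 3 (beyond the scatter) points the same way for a different substituent at that carbon. Here propyl enters where nonyl earlier left, so a step downward beyond the scatter is expected, but not the whole way to the floor. For compound 4 the expected step is a number 50 percentage points lower from compound 3 to compound 4 (beyond the scatter). Compound 4 is estimated at 50%, within 15% to 85%.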

Compound 4, largest response reached (reported as maximal response), in percent of the reference or control that the assay uses: 70%
Estimate against measurement, compound 4: 20 percentage points below; the range from low to high includes it.
By their numbers in this assay, from the lowest: compound 2; then compounds 4 and 1 (each within the scatter of the next); then compound 3.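

In this assay, propyl at this carbon costs only part of the response, a number 30 percentage points lower from compound 3 to compound 4 (beyond the scatter), and the larger loss lies further along the chain, with removal of hexyl giving a number 70 percentage points higher from compound 2 to compound 4 (beyond the scatter). Propyl and carbamoyl at this carbon are not told apart, a number 2 percentage points lower from compound 1 to compound 4 (within the scatter). Nothing available gives a reason for these steps.

Open, as far as these compounds go, is where, between butyl and the long chain of compound 2, the response is lost. Also open, from the compounds shown here alone, is whether an amine or a carboxylic acid in place of carbamoyl at this carbon would retain it.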